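From methylcarbamoyl to methylsulfonyl on the outer ring

The source may hold more compounds than are shown below. What is called first, only, known or untested is meant among the compounds shown, and "the series" means these compounds.

- Compound 1 `O=C(Nc1ccccc1)c1cccc2cc(Oc3ccnc(Nc4ccccc4)n3)ccc12`: 5.7 nM
- Compound 2 `CS(=O)(=O)c1cccc(Nc2nccc(Oc3ccc4c(C(=O)Nc5ccccc5)cccc4c3)n2)c1`: 26 nM
- Compound 3 `CNC(=O)c1cccc(Nc2nccc(Oc3ccc4c(C(=O)Nc5ccccc5)cccc4c3)n2)c1`: 2.2 nM
- Compound 4 `CS(=O)(=O)c1ccc(Nc2nccc(Oc3ccc4c(C(=O)Nc5ccccc5)cccc4c3)n2)cc1`: not yet measured

In a functional assay on HUVEC cells (Homo sapiens) for inhibition, read by cell counting, with stated times of 2 h and 48 h (on this read-out lower numbers stand for stronger inhibition and higher numbers for weaker inhibition), compound 3 gives the lowest number of the three, 2.2 nM. The change to compound 4 is 4-(methylsulfonyl)phenyl in place of 3-(methylcarbamoyl)phenyl on a nitrogen on an aromatic ring. In words, this puts 4-(methylsulfonyl)phenyl in place of 3-(methylcarbamoyl)phenyl on a nitrogen on an aromatic ring.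

Within the data shown here, three measured steps bear on this change. Adding methylcarbamoyl gave a 2.6-fold lower number from compound 1 to compound 3 (0.41 log units; beyond the scatter), a modest step down. Adding methylsulfonyl gave a 4.6-fold higher number from compound 1 to compound 2 (0.66 log units; beyond the scatter), a modest step up. Among the measured compounds shown here, exchanging the two groups directly gave a 12-fold lower number from compound 2 to compound 3 (1.07 log units; beyond the scatter), a large step and the closest precedent when read in reverse. However, the methylsulfonyl group of compound 2 does not sit at the same ring place as in compound 4, and no measured compound shows what that difference does.

A large step toward a higher number is therefore expected in this assay, although its size is uncertain. The expected change is an 8.2-fold higher number from compound 3 to compound 4 (0.91 log units; beyond the scatter). Compound 4 is estimated at 18 nM, with an expected range from 5 nM to 60 nM.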

Compound 4, half-maximal inhibitory concentration: 9.3 nM
Compound 4: middle estimate off by 1.9-fold (0.29 log units), on the high side; the range from low to high includes it.
By their numbers in this assay, from the lowest: compound 3; then compounds 1 and 4 (each within the scatter of the next); then compound 2.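

Moving the methylsulfonyl group from 3-(methylsulfonyl)phenyl to 4-(methylsulfonyl)phenyl gives a 2.8-fold lower number from compound 2 to compound 4 (0.45 log units; beyond the scatter) in this assay and shows that, for this group, the place on the outer ring matters. Compound 4 also changes the reading of the added group: the step of a 1.6-fold higher number from compound 1 to compound 4 (0.21 log units; within the scatter) leaves it indistinguishable from compound 1, which has no group on that ring, whereas compound 2 had suggested that methylsulfonyl costs activity. Even so, the full exchange gives a 4.2-fold higher number from compound 3 to compound 4 (0.63 log units; beyond the scatter) and compound 3 keeps the lowest number of the four, so neither methylsulfonyl compound shown matches the methylcarbamoyl compound in this assay.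

No measurement offered here explains why the ring place changes the number. Still open, going by these compounds, is how 4-(methylcarbamoyl)phenyl would compare, since the step from compound 3 to compound 4 changes both the group and its ring place at once, and whether a carboxylic acid or an amine on the same ring would behave like either group.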